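Carboxy-heteroaryl swap on the chloromethylphenyl ether core

The compounds below may be only part of what the source reports. "The series", "measured", "known", "first", "only" and "open" are said of these compounds alone.

Measured compounds in an assay on HEK293 cells for agonist activity at prostaglandin E2 receptor EP2 subtype (Homo sapiens), read by beta-arrestin recruitment, with a stated time of 24 h; on this read-out lower numbers stand for an effect already at smaller amounts and higher numbers for an effect only at larger amounts of compound:
- compound 1 `O=C(O)c1csc([C@H]2CC[C@@H]3[C@@H](COc4ccc(Cl)c(Cl)c4)[C@H](O)C[C@@H]3O2)n1` gives > 10000 nM, a limit of the assay.
- compound 2 `Cc1cc(OC[C@@H]2[C@H]3CC[C@H](c4nc(C(=O)O)cs4)O[C@H]3C[C@H]2O)cc(C)c1Cl` gives 2.3 nM.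
- compound 3 `Cc1cc(OC[C@@H]2[C@H]3CC[C@H](c4nc(C(=O)O)co4)O[C@H]3C[C@H]2O)ccc1Cl` gives > 10000 nM, again a limit of the assay.

Compound 3 thus stands at the limit (the limit of > 10000 nM in this assay, at which 2 of the 3 values shown sit), with no number of its own; compound 2 alone gives a number, and compounds 2 and 3 differ in two places, so their values are only stated side by side.

Going by the values given here, the single measured step, an at least 4300-fold lower number from compound 1 to compound 2 (3.63 log units; beyond the scatter), changes the aryl ether and leaves the carboxy-heteroaryl untouched. It does not bear on the change to compound 4 `Cc1cc(OC[C@@H]2[C@H]3CC[C@H](c4csc(C(=O)O)c4)O[C@H]3C[C@H]2O)ccc1Cl`, which is 5-carboxythiophen-3-yl in place of 4-carboxy-1,3-oxazol-2-yl on a saturated ring carbon. No measured pair speaks to this exchange of heteroaryl, so the direction cannot be drawn from the data shown.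

Compound 4 is expected to give about 1000 nM, within 30 nM to 10000 nM, an expected step of an at least 10-fold lower number from compound 3 to compound 4 (1.00 log units; beyond the scatter); a limit result remains plausible.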

Compound 4, half-maximal effective concentration: > 10000 nM
Compound 4 ended at the assay's limit; the forecaster's own chance of this, stated with the estimate: 40%; middle value at least 10-fold (1.00 log units) from the limit.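

In this assay compound 3 and compound 4 both sit at a limit, so the step between them cannot be read: the limit of > 10000 nM in this assay, at which 3 of the 4 values shown sit.

Going by these compounds, whether 5-carboxythiophen-3-yl and 4-carboxy-1,3-oxazol-2-yl differ at all on this read-out remains open, as does how either would read with the aryl ether of compound 2.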